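The source may report more compounds than this note shows. Statements on the series, on what has been measured and on what is new or still open speak of the compounds shown alone.

Working notes on the series. In a functional assay on HOS cells (Homo sapiens) for inhibition, read by MTT assay, with a stated time of 72 h (on this read-out higher numbers stand for weaker inhibition and lower numbers for stronger inhibition), compound 1 (`COc1ccc(NC(=O)CCC(=O)OCCCCCCSc2ccc([N+](=O)[O-])c3nonc23)cc1OC`) gives 1390 nM and compound 2 (`CN(C)CCCNC(=O)CCC(=O)OCCCCCCSc1ccc([N+](=O)[O-])c2nonc12`) gives 1850 nM as its number, so compound 2 stands within the scatter of compound 1 and the two are not separated. Among the measured compounds shown here, the only measured step is a 1.3-fold higher number from compound 1 to compound 2 (0.12 log units; within the scatter) for 3-(dimethylamino)propyl in place of 3,4-dimethoxyphenyl on an amide-type nitrogen. Next in line is compound 3 (`CN(C)CCNC(=O)CCC(=O)OCCCCCCSc1ccc([N+](=O)[O-])c2nonc12`), which differs from compound 2 by dimethylamino in place of (dimethylamino)methyl on a saturated chain carbon, two bonds along the chain from an amide-type nitrogen and can also be read as 3-(dimethylamino)propyl going to 2-(dimethylamino)ethyl. For the measured compounds named here, no measured step covers this exact change, so the evidence is thin. Going by the values given here, the one step available, a 1.3-fold higher number from compound 1 to compound 2 (0.12 log units; within the scatter) at the same amide-type nitrogen, exchanged an entire substituent and stayed within the scatter. On that basis, no change beyond the scatter is expected in this assay here, and no clear direction can be assigned. The expected step is a 1.1-fold lower number from compound 2 to compound 3 (0.04 log units; within the scatter) and it should not be read as a real difference. For compound 3 the estimated value is 1700 nM (expected range 800 nM to 3800 nM).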

Compound 3, half-maximal inhibitory concentration: 5020 nM
Compound 3: the middle estimate sits 3.0-fold (0.47 log units) below what was measured; the measured number lies above the stated range.
By their numbers in this assay, from the lowest: compounds 1 and 2 (each within the scatter of the next); then compound 3.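

In this assay, the chain on the amide-type nitrogen proves not to be neutral: 2-(dimethylamino)ethyl in place of 3-(dimethylamino)propyl gives a 2.7-fold higher number from compound 2 to compound 3 (0.43 log units; beyond the scatter), a modest weakening, whereas the earlier exchange of an entire substituent at this nitrogen stayed within the scatter. The same group also separates from 3,4-dimethoxyphenyl, with a 3.6-fold higher number from compound 1 to compound 3 (0.56 log units; beyond the scatter), so this position does respond to what it carries, and the small change from (dimethylamino)methyl to dimethylamino counts for more here than the larger exchange did. No supporting data bear on why this change in the chain shifts the number.

Open, on these data alone, is whether a longer chain, such as 4-(dimethylamino)butyl, would stay within the scatter of compound 2 or move away from it in either direction. Also open, as far as these compounds go, is how a morpholine at the end of the 2-carbon or 3-carbon chain, or a plain butyl group with no amine, would read at the same amide-type nitrogen, which would show whether the terminal dimethylamino matters or the chain length alone.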